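Pyridin-3-yl for trifluoromethyl in a Caco-2 permeability series

This account rests on a few compounds, and the source may have more. Where it says the series, first, only, none or still open, it means among the compounds named here.

Compound 1 `CNC(=O)c1cc(Oc2ccc3nc(Nc4cccc(C(C)(C)C)c4)ncc3c2)ccn1`: in an ADME assay on Caco-2 cells (Homo sapiens) for permeability, in the apical to basolateral direction (on this read-out higher numbers stand for higher permeability and lower numbers for lower permeability), compound 1 gives < 1 10^-6 cm/s, a limit of the assay.
Compound 2 `CNC(=O)c1cc(Oc2ccc3nc(Nc4cccc(Cl)c4)ncc3c2)ccn1`: in this assay compound 2 gives < 1 10^-6 cm/s, a limit of the assay.
Compound 3 `CNC(=O)c1cc(Oc2ccc3nc(Nc4ccc(C(F)(F)F)cc4)ncc3c2)ccn1`: in this assay compound 3 gives < 1 10^-6 cm/s, a limit of the assay.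

Compound 3 therefore stands at the floor of this assay, and so do its two companions, as the limit of < 1 10^-6 cm/s in this assay, at which 3 of the 3 values shown sit, records. The measured steps bear on the question only indirectly: the step that the two limits leave unreadable from compound 1 to compound 2, the step that the two limits leave unreadable from compound 1 to compound 3 and the step that the two limits leave unreadable from compound 2 to compound 3 are all unreadable, each sitting between two limits, so no size can be taken from them.

The unmeasured compound 4 `CNC(=O)c1cc(Oc2ccc3nc(Nc4ccc(-c5cccnc5)cc4)ncc3c2)ccn1` differs from compound 3 by pyridin-3-yl in place of trifluoromethyl on an aromatic carbon. The three measured compounds give no readable step in either direction, so no shift beyond the scatter is expected, and compound 3 leaves room only to read an upward step if one occurs. Compound 4 is estimated at 0.6 10^-6 cm/s, between 0.2 10^-6 cm/s and 2 10^-6 cm/s, which corresponds to an expected step that the limit leaves unreadable from compound 3 to compound 4 that may again end at the limit.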

Compound 4, apparent permeability: < 1 10^-6 cm/s
Compound 4: only a limit was reported (the forecaster's own chance of this, stated with the estimate: 70%); the middle value does not contradict the limit.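

Compound 3 and compound 4 both rest on a limit in this assay, so no step can be read between them, nor among the other compounds: the limit of < 1 10^-6 cm/s in this assay, at which 4 of the 4 values shown sit. The compounds shown leave open where each truly lies and which change, if any, would give a readable value.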